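The source may hold more compounds than are shown below. What is called first, only, known or untested is meant among the compounds shown, and "the series" means these compounds.

Of the compounds shown here, three that share one core have been tested in an assay on cells for antagonist activity at transient receptor potential cation channel subfamily V member 1 (Homo sapiens), read by FLIPR and calcium flux, with a stated time of 6 min; a lower number here means a stronger inhibitor, a higher number a weaker inhibitor. Compound 1 `CCCOc1nc(C(C)(C)C)ccc1CNC(=O)C(C)c1ccc(NS(C)(=O)=O)c(F)c1` gives 1.7 nM in this assay. Compound 2 `CCCCCCOc1nc(C(C)(C)C)ccc1CNC(=O)C(C)c1ccc(NS(C)(=O)=O)c(F)c1` gives 2.7 nM. Compound 3 `CC(C(=O)NCc1ccc(C(C)(C)C)nc1SC1CCCC1)c1ccc(NS(C)(=O)=O)c(F)c1` gives 2.5 nM, the second highest of the three numbers, nearest to compound 2 and furthest from compound 1. Every step among them, namely a 1.6-fold higher number from compound 1 to compound 2 (0.20 log units; within the scatter), a 1.5-fold higher number from compound 1 to compound 3 (0.17 log units; within the scatter) and a 1.1-fold lower number from compound 2 to compound 3 (0.03 log units; within the scatter), falls within the scatter, so the three numbers cannot be told apart with confidence.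

Compound 4 `CC(C(=O)NCc1ccc(C(C)(C)C)nc1SCc1ccccc1)c1ccc(NS(C)(=O)=O)c(F)c1` differs from compound 3 in one place: benzyl in place of cyclopentyl on a sulfur. Among the compounds with values here, no measured step alters the group on that sulfur, so no step bears on it directly. The swaps already seen at this side of the core, propoxy or hexyloxy to cyclopentylsulfanyl, moved the number only within the scatter, and exchanging a ring for another ring at the same position is expected to behave alike. The expected step of no change at the digits printed from compound 3 to compound 4 (within the scatter) is therefore within the scatter. Compound 4 is expected to give about 2.5 nM, in a range from 1 nM to 6.5 nM.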

Compound 4, inhibition constant: 4 nM
Compound 4: the middle estimate sits 1.6-fold (0.20 log units) below what was measured; the measured number falls inside the stated range.
By their numbers in this assay, from the lowest: compounds 1, 3, 2 and 4 (each within the scatter of the next, the first and the last beyond it).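

Benzyl in place of cyclopentyl on a sulfur gives a 1.6-fold higher number from compound 3 to compound 4 (0.20 log units; within the scatter) in this assay, so this sulfur can carry a six-membered aromatic ring as well as a five-membered non-aromatic one with no change that can be told from the scatter. Benzylsulfanyl in place of hexyloxy gives a 1.5-fold higher number from compound 2 to compound 4 (0.17 log units; within the scatter), while benzylsulfanyl in place of propoxy gives a 2.4-fold higher number from compound 1 to compound 4 (0.37 log units; beyond the scatter), the first step in this series to pass beyond the scatter, though only modestly. Nothing at hand explains that modest gap.

Benzyloxy and cyclopentyloxy would show whether the sulfur itself matters, since each would keep the same group on an oxygen. A sulfur carrying a chain that ends in an amine or a carboxylic acid remains an open case at this position.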